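The source may report more compounds than this note shows. Statements on the series, on what has been measured and on what is new or still open speak of the compounds shown alone.

Compound 1 `O=C1CCC(=O)N1C[C@H]1CN(c2ccc(-n3cc(-c4ccccn4)cn3)c(F)c2)C(=O)O1` — in an ADME assay on HEK293-A cells (Homo sapiens) for cytotoxicity, read by MTT assay, with a stated time of 48 h (a higher number here means a weaker inhibitor, a lower number a stronger inhibitor), compound 1 gives > 400 ug/mL, which is a limit of the assay and not a number.
Compound 2 `O=C1CNC(=O)N1C[C@H]1CN(c2ccc(-n3cc(-c4ccccn4)cn3)c(F)c2)C(=O)O1` — compound 2 gives > 400 ug/mL, again only a limit.
Compound 3 `CC(=O)OC[C@H]1CN(c2ccc(-n3cc(-c4ccccn4)cn3)c(F)c2)C(=O)O1` — compound 3 gives > 400 ug/mL, likewise a limit.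

Compound 1 thus stands at a limit in this assay, and the two further values are limits as well (the limit of > 400 ug/mL in this assay, at which 3 of the 3 values shown sit). Compound 4 `NC(=O)[C@H]1CN(c2ccc(-n3cc(-c4ccccn4)cn3)c(F)c2)C(=O)O1` differs from compound 1 as follows: carbamoyl in place of (2,5-dioxopyrrolidin-1-yl)methyl on a saturated ring carbon. The three measured steps bearing on this change, a step that the two limits leave unreadable from compound 1 to compound 2, a step that the two limits leave unreadable from compound 1 to compound 3 and a step that the two limits leave unreadable from compound 2 to compound 3, are all left unreadable by the limits, so no size or direction can be taken from them. Nothing in the data points to a step beyond the scatter. Compound 4 is therefore expected to give 400 ug/mL (range 200 ug/mL to 800 ug/mL), most probably reported once more as a limit. The expected step of a number no higher from compound 1 to compound 4 (the limit leaves the size open) is estimated as none beyond the scatter.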

Compound 4, half-maximal inhibitory concentration: 152 ug/mL
The estimate for compound 4 lay 2.6-fold (0.42 log units) above the measured number; the measured number lies below the stated range.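

Carbamoyl on the saturated ring carbon next to the ring oxygen gives the first readable change at this position in this assay: an at least 2.6-fold lower number from compound 1 to compound 4 (0.42 log units; beyond the scatter), an at least 2.6-fold lower number from compound 2 to compound 4 (0.42 log units; beyond the scatter) and an at least 2.6-fold lower number from compound 3 to compound 4 (0.42 log units; beyond the scatter). The steps among compound 1, compound 2 and compound 3 cannot be read, because all three stand at a limit: the limit of > 400 ug/mL in this assay, at which 3 of the 4 values shown sit.

The compounds shown leave open whether a carboxylic acid, an amine or a carbamoylmethyl chain on this ring carbon would also give a number or return to the limit. They also do not separate the carbamoyl group itself from the loss of the chain carbon that the other three compounds carry.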